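A few compounds are considered here, and "the series" means these few. Any claim that something is new, unique, unknown or untested is made for them only; others in the source may bear on it.

Measured compounds:
compound 1 `COc1ccc(C(=O)Nc2cccc(-c3oc4cc(-c5ccc(F)cc5)ccc4c(=O)c3O)c2)cc1` — 16500 nM
compound 2 `O=C(Nc1cccc(-c2oc3cc(-c4ccc(F)cc4)ccc3c(=O)c2O)c1)c1ccc(F)cc1F` — 11200 nM
compound 3 `COc1cccc(C(=O)Nc2cccc(-c3oc4cc(-c5ccc(F)cc5)ccc4c(=O)c3O)c2)c1` — 9160 nM

All three values come from a functional assay on MDA-MB-231 cells (Homo sapiens) for antiproliferative activity, read by CCK-8 assay, with a stated time of 72 h; a higher number here means a weaker inhibitor, a lower number a stronger inhibitor. The compounds share one core and differ only in the aryl group attached to the carbonyl carbon of the amide. In this assay compound 2 gives 11200 nM; its number sits alongside those of compound 1 and compound 3, with the steps of a 1.5-fold lower number from compound 1 to compound 2 (0.17 log units; within the scatter) and a 1.2-fold lower number from compound 2 to compound 3 (0.09 log units; within the scatter) both within the scatter, so no order among the three can be claimed. The remaining step, a 1.8-fold lower number from compound 1 to compound 3 (0.26 log units; within the scatter), is also within the scatter.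

Compound 4 `O=C(Nc1cccc(-c2oc3cc(-c4ccc(F)cc4)ccc3c(=O)c2O)c1)c1cccc(F)c1` is not yet measured. Its difference from compound 2: 3-fluorophenyl in place of 2,4-difluorophenyl on a carbonyl carbon. Every measured step bears on this change, since each exchanges the aryl on the carbonyl carbon; all three were within the scatter. Going by the values given here, nothing among the measured compounds indicates that swapping one fluorinated or methoxylated aryl for another at this site moves the number beyond the scatter. No step beyond the scatter is therefore expected for compound 4. Compound 4 is estimated to give 10000 nM, with a range from 5000 nM to 20000 nM. The expected step is a 1.1-fold lower number from compound 2 to compound 4 (0.05 log units; within the scatter).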

Compound 4, half-maximal inhibitory concentration: 2510 nM
The estimate for compound 4 lay 4.0-fold (0.60 log units) above the measured number, outside the stated range (below it).
By their numbers in this assay, from the lowest: compound 4; then compounds 3, 2 and 1 (each within the scatter of the next).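

In this assay, the aryl group on the carbonyl carbon of the amide proves able to move the number beyond the scatter, which the earlier exchanges at this site did not show: 3-fluorophenyl stands apart from 2,4-difluorophenyl with a 4.5-fold lower number from compound 2 to compound 4 (0.65 log units; beyond the scatter), and from 4-methoxyphenyl with a 6.6-fold lower number from compound 1 to compound 4 (0.82 log units; beyond the scatter). Fluoro in place of methoxy on an aromatic carbon also matters here, with a 3.6-fold lower number from compound 3 to compound 4 (0.56 log units; beyond the scatter), so compound 4 has the lowest number of the set, although each step is modest. No measurement offered here accounts for why this one aryl group differs from the other three.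

The exchange from 2,4-difluorophenyl to 3-fluorophenyl alters both the number of fluorines and their placing, so the compounds shown cannot say which of the two carries the step. On these data alone, it also remains open whether the step is particular to fluoro, and how an unsubstituted phenyl, a chloro or nitrile on the aryl ring, or an aryl group carrying an amine or a carboxylic acid would read at this site.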